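Amide aryl variation on the shared core

The source may hold more compounds than are shown below. What is called first, only, known or untested is meant among the compounds shown, and "the series" means these compounds.

Compound 1 `O=C(Nc1cc(-c2ccccc2)nn1-c1ccccc1)c1cccc(F)c1` sits lowest of the two numbers in an assay on isolated protein with metabotropic glutamate receptor 5 (Rattus norvegicus) as the target (a lower number here means that less compound is needed, a higher number that more compound is needed for the effect), giving 65 nM. Compound 2 `O=C(Nc1cc(-c2ccccc2)nn1-c1ccccc1)c1ccc(Cl)cc1` gives 100 nM in this assay, and a 1.5-fold higher number from compound 1 to compound 2 (0.19 log units; within the scatter). Compound 3 `O=C(Nc1cc(-c2ccccc2)nn1-c1ccccc1)c1ccccc1O` gives > 10000 nM in this assay, which is a limit of the assay and not a number. From it, an at least 150-fold higher number from compound 1 to compound 3 (2.18 log units; beyond the scatter) and an at least 100-fold higher number from compound 2 to compound 3 (2.00 log units; beyond the scatter).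

Compound 4 `O=C(Nc1cc(-c2ccccc2)nn1-c1ccccc1)c1ccccn1` differs from compound 1 by pyridin-2-yl in place of 3-fluorophenyl on a carbonyl carbon. Among the compounds with values here, the measured steps show one ring change tolerated and one not; the entering group brings a ring nitrogen in place of the departing fluorine, a change none of the measured steps tests directly. A modest loss is expected, a 3.8-fold higher number from compound 1 to compound 4 (0.59 log units; beyond the scatter), so compound 4 is estimated at 250 nM, within 50 nM to 2500 nM.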

Compound 4, half-maximal effective concentration: 585 nM
For compound 4 the middle estimate is 2.3-fold (0.37 log units) below the measured one; measured number inside the range.
By their numbers in this assay, from the lowest: compounds 1 and 2 (each within the scatter of the next); then compound 4. At a limit, above all of these: compound 3.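

Pyridin-2-yl on the carbonyl carbon gives a step beyond the scatter, which 3-fluorophenyl and 4-chlorophenyl did not give against each other: a 9.0-fold higher number from compound 1 to compound 4 (0.95 log units; beyond the scatter), and a 5.9-fold higher number from compound 2 to compound 4 (0.77 log units; beyond the scatter). This ring still stays clear of the 2-hydroxyphenyl result, an at least 17-fold lower number from compound 3 to compound 4 (1.23 log units; beyond the scatter). Compound 3 remains a limit and not a number: the limit of > 10000 nM in this assay, at which 1 of the 4 values shown sits.

The compounds shown do not separate the effect of the entering ring nitrogen from that of the departing fluorine. From the compounds shown here alone, how pyridin-3-yl, or an amine or carboxylic acid on this ring, would read stays open.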